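Dimethoxyphenyl carbinol diastereomer in the tetrahydropyran series

The source may hold more compounds than are shown below. What is called first, only, known or untested is meant among the compounds shown, and "the series" means these compounds.

For the measured compounds named here, compound 3 `COc1ccc(/C=C/C[C@H]2C[C@@H]([C@@H](O)c3ccccc3)CO[C@@H]2c2ccc(OC)c(OC)c2)cc1OC` holds the lowest number of the three measured members: in a functional assay on HeLa cells (Homo sapiens) for cytotoxicity, read by WST assay, with a stated time of 48 h (on this read-out lower numbers stand for stronger inhibition and higher numbers for weaker inhibition), compound 3 gives 15500 nM. Compound 1 `COc1ccc(/C=C/C[C@H]2C[C@H]([C@H](O)c3ccc(OC)c(OC)c3)CO[C@@H]2c2ccc(OC)c(OC)c2)cc1OC` gives 34600 nM and compound 2 `COc1ccc([C@H](O)[C@H]2CO[C@H](c3ccc(OC)c(OC)c3)[C@@H](C/C=C/c3ccc(OC)c(OC)c3)C2)cc1` gives 46000 nM, both beyond the scatter from compound 3.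

Compound 4 `COc1ccc(/C=C/C[C@H]2C[C@@H]([C@@H](O)c3ccc(OC)c(OC)c3)CO[C@@H]2c2ccc(OC)c(OC)c2)cc1OC` differs from compound 3 in one place: 3,4-dimethoxyphenyl in place of phenyl on a saturated chain carbon bound to an oxygen on a saturated carbon and a saturated ring carbon. Going by the values given here, the one measured step that bears on this change is a 3.0-fold lower number from compound 2 to compound 3 (0.47 log units; beyond the scatter), where removing a single methoxy lowered the number; compound 4 adds two methoxy groups at the same place, so the reverse direction is expected, a higher number. Compound 1 carries the same 3,4-dimethoxyphenyl group at the carbinol with a different arrangement of the ring centres, and its value of 34600 nM points to the same region.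

The estimate for compound 4 is therefore a higher number, a 1.9-fold higher number from compound 3 to compound 4 (0.29 log units; within the scatter), landing at 30000 nM with an expected range of 12000 nM to 70000 nM.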

Compound 4, half-maximal inhibitory concentration: 23800 nM
Compound 4: middle estimate off by 1.3-fold (0.10 log units), on the high side, within the range that was stated.
By their numbers in this assay, from the lowest: compounds 3, 4, 1 and 2 (each within the scatter of the next, the first and the last beyond it).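

In this assay, 3,4-dimethoxyphenyl in place of phenyl at the carbinol carbon gives a 1.5-fold higher number from compound 3 to compound 4 (0.19 log units; within the scatter), so this larger replacement does not separate the pair beyond the scatter. Methoxy in place of hydrogen on the aromatic ring gives a 1.9-fold lower number from compound 2 to compound 4 (0.29 log units; within the scatter), so the step beyond the scatter seen earlier between compound 2 and compound 3 does not recur here, and methoxy substitution at this place shows no steady trend across compounds 2, 3 and 4. Configuration alone, at a saturated ring carbon and a saturated chain carbon, gives a 1.5-fold lower number from compound 1 to compound 4 (0.16 log units; within the scatter), which also stays within the scatter: the fact that compounds 1 and 4 differ only in the configuration as drawn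

Every group shown at this carbon is a phenyl ring with or without methoxy, so the effect of an amine or a carboxylic acid on that ring stays open. Also open, as far as these compounds go, is whether a longer chain between the carbinol carbon and the ring would shift the number beyond the scatter.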